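Cyclopropyl to Isopropyl on the Ring Nitrogen: an Expectation

The source may report more compounds than this note shows. Statements on the series, on what has been measured and on what is new or still open speak of the compounds shown alone.

Compound 1 `CC(C)CNc1nc(/C=C/c2ccccc2)nc2ccsc12`: > 1000000 nM
Compound 2 `COc1cc(/C=C/c2nc(NC3CC3)c3sccc3n2)cc(OC)c1OC`: > 1000000 nM

In a functional assay on L02 cells (Homo sapiens) for inhibition, read by Griess assay, with stated times of 1 h and 24 h (on this read-out higher numbers stand for weaker inhibition and lower numbers for stronger inhibition), compound 1 gives only a limit, > 1000000 nM. In this assay compound 2 likewise gives only a limit, > 1000000 nM. Going by the values given here, both values therefore sit at the limit of > 1000000 nM in this assay, at which 2 of the 2 values shown sit, and no step between measured compounds can be read.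

Compound 3 `COc1cc(/C=C/c2nc(NC(C)C)c3sccc3n2)cc(OC)c1OC` differs from compound 2 by isopropyl in place of cyclopropyl on a nitrogen on an aromatic ring. In this assay this change is expected to give no step beyond the usual scatter. Compound 3 is thus estimated at 1000000 nM, within 300000 nM to 3000000 nM, most probably reported again as a limit. The expected step is a number no higher from compound 2 to compound 3 (the limit leaves the size open).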

Compound 3, half-maximal inhibitory concentration: > 1000000 nM
Compound 3 ended at the assay's limit (the forecaster's own chance of this, stated with the estimate: 85%); the middle value lies on the limit itself.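

Compound 3, like compound 2, gives only a limit in this assay, so no step between them can be read: the limit of > 1000000 nM in this assay, at which 3 of the 3 values shown sit.

The compounds shown leave open what isopropyl in place of cyclopropyl does to inhibition, and how strongly any of them inhibits.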